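A furan-bearing phenyl group on the shared core

This account rests on a few compounds, and the source may have more. Where it says the series, first, only, none or still open, it means among the compounds named here.

Measured in a functional assay on HL-60 cells (Homo sapiens) for inhibition, read by MTT assay, with a stated time of 72 h; a lower number here means a stronger inhibitor, a higher number a weaker inhibitor:
- compound 1 `COc1cc(OC)cc(N2CCN(C(=O)c3onc(C)c3-c3ccccc3)CC2)c1`: 152 nM
- compound 2 `COc1cc(OC)cc(N2CCN(C(=O)c3onc(C)c3-c3cccc(F)c3)CC2)c1`: 152 nM

Compound 1 and compound 2 stand level, with compound 2 at 152 nM. Going by the values given here, the only measured step, no change at the digits printed from compound 1 to compound 2 (within the scatter), is fluoro in place of hydrogen on an aromatic carbon, and it lies within the scatter. Compound 3 `COc1cc(OC)cc(N2CCN(C(=O)c3onc(C)c3-c3ccc(-c4ccco4)cc3)CC2)c1` brings a different change: 4-(furan-2-yl)phenyl in place of 3-fluorophenyl on an aromatic carbon. Among the compounds with values here, no measured step shows what a furan-2-yl group does, so that step bears on it only weakly. A modest weakening is expected in this assay, estimated as a 1.4-fold higher number from compound 2 to compound 3 (0.16 log units; within the scatter), though its direction is uncertain. The estimate for compound 3 is 220 nM, within 70 nM to 700 nM.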

Compound 3, half-maximal inhibitory concentration: 191 nM
Compound 3: the middle estimate sits 1.2-fold (0.06 log units) above what was measured, and the stated range covers the measured number.
By their numbers in this assay, from the lowest: compounds 1, 2 and 3 (each within the scatter of the next).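

In this assay, the aromatic carbon of the five-membered ring takes 4-(furan-2-yl)phenyl in place of 3-fluorophenyl with a 1.3-fold higher number from compound 2 to compound 3 (0.10 log units; within the scatter), a step within the scatter. Furan-2-yl in place of hydrogen gives a 1.3-fold higher number from compound 1 to compound 3 (0.10 log units; within the scatter), also within the scatter, so this site accepts a second aromatic ring on the phenyl group without a step beyond the scatter among these compounds. No evidence is available to explain this result. The compounds shown leave open whether an amine, a carboxylic acid or a longer chain on that phenyl group would give a step beyond the scatter.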